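Amide-nitrogen aryl variation around compound 3

The source may report more compounds than this note shows. Statements on the series, on what has been measured and on what is new or still open speak of the compounds shown alone.

Going by the values given here, compound 3 `COc1cccc(NC(=O)CSc2nc(Nc3ccccc3)c3ccccc3n2)c1` is the only member of the series with a number in a functional assay on MDA-MB-231 cells (Homo sapiens) for inhibition, read by MTT assay, with a stated time of 72 h (a higher number here means a weaker inhibitor, a lower number a stronger inhibitor), where compound 3 gives 21700 nM. Compound 1 `O=C(CSc1nc(Nc2ccccc2)c2ccccc2n1)Nc1ccccc1F` reaches only a limit there, > 50000 nM. Compound 2 `O=C(CSc1nc(Nc2ccccc2)c2ccccc2n1)Nc1cccc(F)c1` likewise stops at a limit, > 50000 nM. Among the compounds with values here, both sit at the limit of > 50000 nM in this assay, at which 2 of the 3 values shown sit, so the step that the two limits leave unreadable from compound 1 to compound 2 cannot be read, while an at least 2.3-fold lower number from compound 1 to compound 3 (0.36 log units; beyond the scatter) and an at least 2.3-fold lower number from compound 2 to compound 3 (0.36 log units; beyond the scatter) are the only steps that bear on changes to the aryl on the amide-type nitrogen, and each shows gain on moving to the methoxy compound. Compound 4 `C=CC(=O)Nc1cccc(NC(=O)CSc2nc(Nc3ccccc3)c3ccccc3n2)c1` carries the change ((vinylcarbonyl)amino in place of methoxy on an aromatic carbon). Within the data shown here, no measured pair tests this kind of group. Compound 4 is therefore expected to land near 15000 nM, between 4000 nM and 50000 nM, a step of a 1.4-fold lower number from compound 3 to compound 4 (0.16 log units; within the scatter).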

Compound 4, half-maximal inhibitory concentration: 10200 nM
Compound 4: middle estimate off by 1.5-fold (0.17 log units), on the high side; measured number inside the range.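

On the aryl of the amide-type nitrogen, (vinylcarbonyl)amino gives the lowest number shown so far in this assay, with a 2.1-fold lower number from compound 3 to compound 4 (0.33 log units; beyond the scatter), so this place accepts a group with more heavy atoms than methoxy without loss. The distance from the fluoro compounds is larger, with an at least 4.9-fold lower number from compound 2 to compound 4 (0.69 log units; beyond the scatter) and an at least 4.9-fold lower number from compound 1 to compound 4 (0.69 log units; beyond the scatter). Compound 1 and compound 2 enter these two steps only as limits, not as numbers: the limit of > 50000 nM in this assay, at which 2 of the 4 values shown sit.

On these data alone, whether the gain depends on the vinyl double bond stays open; a saturated propanoylamino group or a plain amine at this place would separate the two. The compounds shown also leave open how the (vinylcarbonyl)amino group behaves with any other group on the anilino phenyl of the shared core.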